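A few compounds are considered here, and "the series" means these few. Any claim that something is new, unique, unknown or untested is made for them only; others in the source may bear on it.

Compound 1, `CCCCOC(=O)CNC(=O)[C@H](CSc1ccc([N+](=O)[O-])cc1[N+](=O)[O-])NC(=O)CC[C@H](NC(=O)CC(C)C)C(=O)OCCCC`, in a toxicity assay on KB cells (Homo sapiens) for cytotoxicity, read by fluorescence, with a stated time of 3 days (a higher number here means that more compound is needed for the effect, a lower number that less compound is needed), gives 59.6 uM.
Compound 2, `CCCCOC(=O)CNC(=O)[C@H](CSc1ccc([N+](=O)[O-])cc1[N+](=O)[O-])NC(=O)CC[C@H](NC(=O)OC)C(=O)OCCCC`, in this assay gives only a limit, > 300 uM.
Compound 3, `CCCCOC(=O)CNC(=O)[C@H](CSc1ccc([N+](=O)[O-])cc1[N+](=O)[O-])NC(=O)CC[C@H](NC(=O)OC(C)(C)C)C(=O)OCCCC`, in this assay gives 70.4 uM.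

Compound 1 holds the lowest of the two numbers, and compound 3 lies within the scatter of it, as a 1.2-fold higher number from compound 1 to compound 3 (0.07 log units; within the scatter) shows. The value of compound 2 is a limit of the assay, not a number (the limit of > 300 uM in this assay, at which 1 of the 3 values shown sits). Compound 4, `CCCCOC(=O)CNC(=O)[C@H](CSc1ccc([N+](=O)[O-])cc1[N+](=O)[O-])NC(=O)CC[C@H](NC(=O)CC(C)(C)C)C(=O)OCCCC`, has not yet been measured. It differs from compound 1 by methyl in place of hydrogen on a saturated chain carbon bound to three saturated chain carbons. Two measured steps change the same carbonyl substituent: an at least 5.0-fold higher number from compound 1 to compound 2 (0.70 log units; beyond the scatter) and a 1.2-fold higher number from compound 1 to compound 3 (0.07 log units; within the scatter). The tert-butoxy step stays within the scatter, and the change to compound 4 is smaller than either, a single added methyl on the isobutyl chain. Compound 4 is therefore expected to fall close to compound 1, with a 1.1-fold lower number from compound 1 to compound 4 (0.03 log units; within the scatter) and no step beyond the scatter. The value of compound 4 is estimated at 55 uM, between 25 uM and 130 uM.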

Compound 4, concentration for half-maximal effect: 250 uM
Estimate against measurement, compound 4: 4.5-fold (0.66 log units) below, outside the stated range (above it).
By their numbers in this assay, from the lowest: compounds 1 and 3 (each within the scatter of the next); then compound 4. At a limit, above all of these: compound 2.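

In this assay a single methyl in place of hydrogen on a saturated chain carbon bound to three saturated chain carbons is not a silent change, for isobutyl to neopentyl gives a 4.2-fold higher number from compound 1 to compound 4 (0.62 log units; beyond the scatter). The earlier compounds shown here had placed isobutyl and tert-butoxy within the scatter of each other, yet neopentyl does not join them, as a 3.6-fold higher number from compound 3 to compound 4 (0.55 log units; beyond the scatter) shows. Compound 2 holds a limit and not a number, and the comparison with it yields only an at least 1.2-fold lower number from compound 2 to compound 4 (0.07 log units; that floor lies within the scatter), so compound 4 cannot be separated from it: the limit of > 300 uM in this assay, at which 1 of the 4 values shown sits.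

The compounds shown leave open whether the higher number belongs to this added methyl alone or to the size of the group on the carbonyl carbon. As far as these compounds go, how a straight pentyl chain or an amine in place of neopentyl would read stays unknown.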